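The source may hold more compounds than are shown below. What is called first, only, known or untested is meant among the compounds shown, and "the series" means these compounds.

Within the data shown here, compound 2 `Cc1ccc(N2CCN(c3ccc(C(=O)/C=C/c4ccccc4)cc3)CC2)cc1` gives 2.85% in a functional assay on the whole organism (strain Kunming) for inhibition, with Mus musculus as the target, with a stated time of 1 h, at a dose of 40 mg/kg by the oral route (on this read-out lower numbers stand for less inhibition and higher numbers for more inhibition at the one dose given (going by the name of the read-out)), the lower of the two numbers measured so far. Among the measured compounds shown here, compound 1 `O=C(/C=C/c1ccccc1)c1ccc(N2CCN(c3cccc(Cl)c3Cl)CC2)cc1` gives 30.7% in this assay, and the one measured step, a number 27.9 percentage points lower from compound 1 to compound 2 (beyond the scatter), is the only guide available. Compound 3 `O=C(/C=C/c1ccccc1)c1ccc(N2CCN(c3ccccc3Cl)CC2)cc1` differs from compound 2 by 2-chlorophenyl in place of 4-methylphenyl on an amine nitrogen in a ring. That single step showed a loss of inhibition when 2,3-dichlorophenyl gave way to 4-methylphenyl; here 2-chlorophenyl, which shares a chlorine with 2,3-dichlorophenyl, replaces 4-methylphenyl, and a gain of inhibition, somewhat smaller than that step, is expected. Compound 3 is therefore expected to give 20%, between 3% and 38%, an expected step of a number 17.2 percentage points higher from compound 2 to compound 3 (beyond the scatter).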

Compound 3, a percentage reported as inhibition, in the whole organism at one dose (the size of the read-out at that dose, not a potency): 4.71%
For compound 3 the middle estimate is 15.3 percentage points above the measured one; measured number inside the range.
By their numbers in this assay, from the lowest: compounds 2 and 3 (each within the scatter of the next); then compound 1.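

In this assay the change from 4-methylphenyl to 2-chlorophenyl gives a number 1.9 percentage points higher from compound 2 to compound 3 (within the scatter) and so one chlorine on this phenyl ring does not set these two compounds apart. Hydrogen in place of chloro on an aromatic carbon gives a number 26 percentage points lower from compound 1 to compound 3 (beyond the scatter) and so, among these compounds, only the one with 2,3-dichlorophenyl stands apart. Nothing available explains this difference. On these data alone, it remains open whether a second chlorine is needed as such, or whether another group on this phenyl ring, such as methoxy or an amine, would also keep the number near that of compound 1.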